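A methyl added to compound 3

The source may hold more compounds than are shown below. What is called first, only, known or untested is meant among the compounds shown, and "the series" means these compounds.

- compound 1 `Cc1cccc(-c2cc(O)c3ccc(C)nc3n2)c1` gives 126 nM
- compound 2 `Cc1ccnc2nc(-c3cccc4ccccc34)cc(O)c12` gives < 10 nM as a limit
- compound 3 `Cc1ccnc2nc(-c3ccc4ccccc4c3)cc(O)c12` gives 437 nM

All three values come from a functional assay on SK-MEL-5 cells (Homo sapiens) for antiproliferative activity (on this read-out lower numbers stand for stronger inhibition of growth and higher numbers for weaker inhibition of growth), and form the whole of the evidence. The reading for compound 2 is < 10 nM and it is a limit of the assay, not a number. Of the two true numbers, compound 3 at 437 nM stands highest, and compound 1 at 126 nM lies lower by more than the scatter.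

Compound 4 `Cc1cc(C)c2c(O)cc(-c3ccc4ccccc4c3)nc2n1` has methyl in place of hydrogen on an aromatic carbon, next to the ring nitrogen (methyl in place of hydrogen on an aromatic carbon). For the measured compounds named here, no measured pair shows this change alone, so no shift beyond the scatter is expected in this assay in either direction. The expected step of a 1.2-fold lower number from compound 3 to compound 4 (0.10 log units; within the scatter) is therefore small. In this assay compound 4 is expected at 350 nM with a wide estimated range (100 nM to 1200 nM).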

Compound 4, concentration for 50% growth inhibition: 2190 nM
For compound 4 the middle estimate is 6.3-fold (0.80 log units) below the measured one, and the stated range ends below it.
By their numbers in this assay, from the lowest: compound 1; then compound 3; then compound 4. At a limit, below all of these: compound 2.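

Methyl in place of hydrogen on an aromatic carbon, next to the ring nitrogen, gives in this assay a step of a 5.0-fold higher number from compound 3 to compound 4 (0.70 log units; beyond the scatter) and so weakens growth inhibition on this core; it is the only change in one place shown. Nothing given here accounts for this loss. Whether the loss belongs to methyl alone or to any group at this position stays open, as an amine or a methoxy group there is not among the compounds shown. Also open, on these data alone, is whether the same methyl would cost as much alongside the other aromatic groups of compound 1 and compound 2.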